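Aryl swap on the imidazole nitrogen, piperidine tail held

This account rests on a few compounds, and the source may have more. Where it says the series, first, only, none or still open, it means among the compounds named here.

Measured so far:
compound 1, `COc1cc2c(Oc3ccc(NC(=O)c4cn(-c5ccc(Cl)cc5)cn4)cc3F)ccnc2cc1OCCCN1CCN(C)CC1`: 4110 nM
compound 2, `COc1cc2c(Oc3ccc(NC(=O)c4cn(-c5cc(C)ccc5C)cn4)cc3F)ccnc2cc1OCCCN1CCCCC1`: 830 nM

In a functional assay on MKN-45 cells (Homo sapiens) for cytotoxicity, read by MTT assay, with a stated time of 72 h (a higher number here means a weaker inhibitor, a lower number a stronger inhibitor), compound 2 gives the lowest of the two numbers; compound 1 gives 4110 nM, a gap beyond the scatter, but the two differ in both the aryl group and the amine tail, so neither change can be credited on its own. Compound 3, `COc1cc2c(Oc3ccc(NC(=O)c4cn(-c5ccc(Cl)cc5)cn4)cc3F)ccnc2cc1OCCCN1CCCCC1`, carries 4-chlorophenyl in place of 2,5-dimethylphenyl on an aromatic nitrogen and shares the piperidine tail of compound 2. Among the measured compounds shown here, with no single-change step known, a move toward compound 1 is expected, a 2.4-fold higher number from compound 2 to compound 3 (0.38 log units; beyond the scatter), in this assay. For compound 3 an estimate of 2000 nM is made, with a range of 700 nM to 6000 nM.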

Compound 3, half-maximal inhibitory concentration: 5910 nM
Compound 3: the middle estimate sits 3.0-fold (0.47 log units) below what was measured, and the stated range covers the measured number.
By their numbers in this assay, from the lowest: compound 2; then compounds 1 and 3 (each within the scatter of the next).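

Read on its own, with the piperidine tail held, 4-chlorophenyl in place of 2,5-dimethylphenyl on an aromatic nitrogen gives a 7.1-fold higher number from compound 2 to compound 3 (0.85 log units; beyond the scatter) in this assay. With 4-chlorophenyl held, piperidin-1-yl in place of 4-methylpiperazin-1-yl gives a 1.4-fold higher number from compound 1 to compound 3 (0.16 log units; within the scatter), so these two tails are not told apart here. No measurement at hand gives a cause for the aryl step. Still open, as far as these compounds go, is how 2,5-dimethylphenyl reads with the 4-methylpiperazin-1-yl tail. Also open, from the compounds shown here alone, is how a morpholine tail, or a phenyl bearing a single methyl on that nitrogen, would read.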